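The source may hold more compounds than are shown below. What is called first, only, known or untested is meant among the compounds shown, and "the series" means these compounds.

Going by the values given here, in a functional assay on HL-60 cells (Homo sapiens) for cytotoxicity, read by luminescence and CellTiter-Glo, with a stated time of 3 days (on this read-out higher numbers stand for weaker inhibition and lower numbers for stronger inhibition), two compounds have numbers so far. Compound 1 `O=C(Nc1ccc(C(F)(F)F)cc1)c1cc(Br)c(-c2ccccc2)cc1O` gives 540 nM and compound 2 `N#Cc1ccc(NC(=O)c2ccc(-c3ccccc3)cc2O)cc1` gives 700 nM. These two values lie within the scatter of each other, so compound 2 cannot be separated from compound 1 on the present numbers. Compound 3 `N#Cc1ccc(NC(=O)c2cc(Br)c(-c3ccccc3)cc2O)cc1` comes from compound 2 through a single change, bromo in place of hydrogen on an aromatic carbon, ortho to a phenyl group and para to a hydroxy group. Among the compounds with values here, no pair of measured compounds shows this change on its own, so the data give no direct size for it in this assay. Within the data shown here, the only guide is indirect: compound 1, which also carries a bromo group, gives 540 nM, a value within the scatter of compound 2 at 700 nM. A step beyond the scatter is therefore not expected in either direction. The estimated change is a 1.3-fold lower number from compound 2 to compound 3 (0.10 log units; within the scatter), which is expected to stay within the scatter. Compound 3 is expected at 550 nM, with an estimated range from 250 nM to 1200 nM.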

Compound 3, half-maximal inhibitory concentration: 700 nM
For compound 3 the middle estimate is 1.3-fold (0.10 log units) below the measured one; the measured number falls inside the stated range.
By their numbers in this assay, from the lowest: compounds 1, 2 and 3 (each within the scatter of the next).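

In this assay, bromo in place of hydrogen on this aromatic carbon, ortho to a phenyl group and para to a hydroxy group, now has a directly measured size, with no change at the digits printed from compound 2 to compound 3 (within the scatter). Compound 3 also forms a second matched pair, with a 1.3-fold higher number from compound 1 to compound 3 (0.11 log units; within the scatter), so cyano and trifluoromethyl cannot be told apart in this assay when the bromo group is present. Nothing measured here bears on why neither step moves beyond the scatter.

What the compounds shown leave open is whether a different group at the bromo position, such as a methoxy group, an amine or a carboxylic acid, would give a number beyond the scatter of these values. Going by these compounds, it also remains open whether cyano and trifluoromethyl would stay indistinguishable with hydrogen at that position, and whether a group such as an amine or a longer chain in their place would separate from them.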